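Swapping a ring on the shared core: expected solubility

A few compounds are considered here, and "the series" means these few. Any claim that something is new, unique, unknown or untested is made for them only; others in the source may bear on it.

Of the compounds shown here, three built on the same core have been measured in a physicochemical assay for solubility, read by HPLC, in phosphate buffer, measured as kinetic solubility, with a stated time of 1 h, at pH 7.4, tested at 250 uM; on this read-out lower numbers stand for lower solubility and higher numbers for higher solubility. Compound 1 `O=C(NCCCCc1ccccc1)n1c2c(oc1=O)CNCC2` gives 230000 nM, compound 2 `CN1CCC(c2ccc3c(c2)oc(=O)n3C(=O)NCCOCc2ccccc2)CC1` gives 73000 nM, and compound 3 `CN1CCC(c2ccc3c(c2)oc(=O)n3C(=O)NCCCCc2ccccc2)CC1=O` gives 20000 nM. Compound 3 therefore stands lowest of the three numbers: compound 2 sits above it by a margin beyond the scatter, and compound 1 lies further above still.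

The next compound, compound 4 `CN1CCN(c2ccc3c(c2)oc(=O)n3C(=O)NCCCCc2ccccc2)CC1`, differs from compound 3 in one place: 4-methylpiperazin-1-yl in place of 1-methyl-2-oxopiperidin-4-yl on an aromatic carbon. Among the measured compounds shown here, no directly measured pair shows this exact change, so the expectation rests on the three numbers already in hand. Since compound 1 and compound 2 both sit well above compound 3 in this assay, an upward step is expected from the change, reaching beyond the usual scatter: the estimated step is a 3.5-fold higher number from compound 3 to compound 4 (0.54 log units; beyond the scatter). Compound 4 is therefore expected to give about 70000 nM in this assay, with a likely range from 25000 nM to 200000 nM.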

Compound 4, solubility: < 1000 nM
Compound 4 gave a limit, no number; the forecaster's own chance of this, stated with the estimate: 10%; middle value at least 70-fold (1.84 log units) from the limit.
By their numbers in this assay, from the lowest: compound 3; then compound 2; then compound 1. At a limit, below all of these: compound 4.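

Putting 4-methylpiperazin-1-yl in place of 1-methyl-2-oxopiperidin-4-yl on this aromatic carbon gives an at least 20-fold lower number from compound 3 to compound 4 (1.30 log units; beyond the scatter) in this assay, so this one position can move the read-out by a large amount while the rest of the molecule stays the same. Compound 4 carries a limit, not a number: the limit of < 1000 nM in this assay, at which 1 of the 4 values shown sits. Among the compounds shown here, the earlier compounds differ from one another in more than one place, so this pair is the first to isolate a single change on the shared core.

As far as these compounds go, it remains open how a morpholine, a piperidine without the methyl group or a carboxylic acid would read at this position. A single pair also cannot give the cause of the step, or tell whether the same swap would act alike with a different chain on the shared core.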